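Urea analogues and solubility: from fluoro to amino

A few compounds are considered here, and "the series" means these few. Any claim that something is new, unique, unknown or untested is made for them only; others in the source may bear on it.

Measured compounds:
compound 1 `Cc1cc(NC(=O)Nc2ccc(F)c(F)c2)c2ccccc2n1` – 500 nM
compound 2 `Cc1cc(NC(=O)Nc2ccc(F)cc2)c2ccccc2n1` – 3700 nM
compound 3 `CSc1ccccc1NC(=O)Nc1cc(C)nc2ccccc12` – 21000 nM

In a physicochemical assay for solubility, at pH 7.4 (on this read-out lower numbers stand for lower solubility and higher numbers for higher solubility), compound 2 gives 3700 nM, the second highest of the three numbers. Its nearest neighbour is compound 3, which in this assay gives 21000 nM, a number well beyond the scatter above it. Compound 1 lies furthest away and in this assay gives 500 nM.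

The unmeasured compound 4 `Cc1cc(NC(=O)Nc2ccc(N)cc2)c2ccccc2n1` differs from compound 2 in one place: amino in place of fluoro on an aromatic carbon.

Within the data shown here, only one measured step bears on this change: a 7.4-fold higher number from compound 1 to compound 2 (0.87 log units; beyond the scatter). That step showed that removing a fluoro from the phenyl ring of the urea moved the number upward by a modest but clear amount. The present change again removes a fluoro, and the amino that enters brings one hydrogen-bond donor and one hydrogen-bond acceptor. On that basis a step upward in this assay beyond the scatter is expected, of roughly the size seen before or somewhat larger.

Compound 4 is therefore estimated at 15000 nM in this assay, within a range from 4000 nM to 60000 nM. This estimate corresponds to an expected step of a 4.1-fold higher number from compound 2 to compound 4 (0.61 log units; beyond the scatter).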

Compound 4, solubility: 18500 nM
Compound 4: middle estimate off by 1.2-fold (0.09 log units), on the low side; the measured number falls inside the stated range.
By their numbers in this assay, from the lowest: compound 1; then compound 2; then compounds 4 and 3 (each within the scatter of the next).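

In this assay, amino in place of fluoro on the aromatic carbon para to a large group gives a 5.0-fold higher number from compound 2 to compound 4 (0.70 log units; beyond the scatter). The earlier step, a 7.4-fold higher number from compound 1 to compound 2 (0.87 log units; beyond the scatter), had only hydrogen in place of fluoro, so the new step is the first among these compounds in which a group other than hydrogen enters on this ring, and the number again moves upward by a modest step beyond the scatter. This also shows that the number in this assay responds to a change at this particular place on the ring, although nothing gathered here explains why the step has this direction or size.

The compounds shown leave open how much of the step belongs to the fluoro leaving and how much to the amino entering, a question that a plain phenyl at this place, with hydrogen on that carbon, would separate. They also leave open whether a methylamino, a hydroxyl or a carboxylic acid at the same place would move the number in the same direction, and compound 3 differs from compound 4 in more than one place and cannot answer this.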